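Butyl for Cyclopropyl on the Alkyne of a Pyrimidinedione Core

This account rests on a few compounds, and the source may have more. Where it says the series, first, only, none or still open, it means among the compounds named here.

Measured so far:
compound 1, `CCC#Cc1c[nH]c(=O)[nH]c1=O`: 120000 nM
compound 2, `O=c1[nH]cc(C#CC2CC2)c(=O)[nH]1`: 101000 nM

Both compounds share one core and differ only in the group on the triple-bonded carbon. In an ADME assay on MRC5 cells (Homo sapiens) for cytotoxicity, read by MTT assay (a lower number here means that less compound is tolerated, a higher number that more compound is tolerated), compound 1 gives 120000 nM, and compound 2 gives 101000 nM. The one step recorded between them, a 1.2-fold lower number from compound 1 to compound 2 (0.07 log units; within the scatter), is within the scatter, so on the numbers shown compound 2 stands at a level indistinguishable from compound 1; the two numbers cannot be told apart.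

Compound 3, `CCCCC#Cc1c[nH]c(=O)[nH]c1=O`, is not yet measured in this assay. The change from compound 2 is butyl in place of cyclopropyl on a triple-bonded carbon. Among the measured compounds shown here, the only measured step that bears on this change is the one at the same place, from compound 1 to compound 2, and that step stayed within the scatter. A second exchange of the group on the triple-bonded carbon is therefore expected to move this assay little, if at all, with no clear direction.

Compound 3 is expected to give about 100000 nM, within a range from 50000 nM to 200000 nM. The expected step is a 1.0-fold lower number from compound 2 to compound 3 (0.00 log units; within the scatter), which lies within the scatter.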

Compound 3, half-maximal cytotoxic concentration: 113000 nM
The estimate for compound 3 lay 1.1-fold (0.05 log units) below the measured number; the measured number falls inside the stated range.
By their numbers in this assay, from the lowest: compounds 2, 3 and 1 (each within the scatter of the next).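

Within this assay, the exchange of cyclopropyl for butyl on a triple-bonded carbon gives a 1.1-fold higher number from compound 2 to compound 3 (0.05 log units; within the scatter) and so removes the three-membered ring without a difference that can be read, which shows that an open chain and this ring cannot be told apart at this position. Lengthening the chain, with ethyl in place of hydrogen on a saturated chain carbon, two bonds along the chain from a triple-bonded carbon, gives a 1.1-fold lower number from compound 1 to compound 3 (0.03 log units; within the scatter) and likewise leaves no readable difference, so ethyl and butyl cannot be told apart here either, and all three groups now stand within the scatter of one another. Nothing available accounts for this flat result.

All three groups are built of carbon alone, so the compounds shown leave open whether an amine, a carboxylic acid or a phenyl ring on the triple-bonded carbon would stay within the same scatter. They also leave open whether a chain longer than butyl would do so, and they say nothing about any exchange elsewhere on the shared core.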